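Sulfamoyl for methylsulfonyl on a second core

The compounds below may be only part of what the source reports. "The series", "measured", "known", "first", "only" and "open" are said of these compounds alone.

Compound 1 `CC(=O)Oc1ccc(/C=C/C(=O)OCCSc2nc(-c3ccc(S(C)(=O)=O)cc3)n(-c3ccc(F)cc3)n2)cc1OC(C)=O` and compound 2 `CC(=O)Oc1ccc(/C=C/C(=O)OCCSc2nc(-c3ccc(S(N)(=O)=O)cc3)n(-c3ccc(F)cc3)n2)cc1OC(C)=O` share one core; compound 3 `CS(=O)(=O)c1ccc(-c2nc(SCCOC(=O)/C=C/c3ccc(O)c(O)c3)nn2-c2ccccc2)cc1` and compound 4 `NS(=O)(=O)c1ccc(-c2nc(SCCOC(=O)/C=C/c3ccc(O)c(O)c3)nn2-c2ccccc2)cc1` share another. How the core of compound 3 differs from the core of compound 1 is not broken down here.

In a functional assay on Caco-2 cells (Homo sapiens) for antiproliferative activity, read by MTT assay, with a stated time of 72 h (on this read-out higher numbers stand for weaker inhibition and lower numbers for stronger inhibition), compound 1 gives 12800 nM, and compound 2 gives 11000 nM. The change between them is amino in place of methyl on a sulfonyl sulfur, and it gave a 1.2-fold lower number from compound 1 to compound 2 (0.07 log units; within the scatter). In this assay compound 3 gives 14800 nM; its number lies within the scatter of the numbers for compound 1 and compound 2, so no order among the three can be read from these values.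

Compound 4 carries the same change against compound 3: amino in place of methyl on a sulfonyl sulfur. The place reads alike in both pairs, a sulfonyl sulfur whose other neighbours are aromatic carbon, so this is the same change, occurring twice among the compounds shown. The step expected from compound 3 to compound 4 in this assay is a 1.2-fold lower number from compound 3 to compound 4 (0.07 log units; within the scatter), set beside the earlier one because a 1.2-fold lower number from compound 1 to compound 2 (0.07 log units; within the scatter) stayed within the scatter. This rests on a single precedent on a different core, and the two cores are not compared in counted terms here. Compound 4 is estimated at 12500 nM in this assay, with the expected range running from 6500 nM to 24000 nM.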

Compound 4, half-maximal inhibitory concentration: 15000 nM
Compound 4: the middle estimate sits 1.2-fold (0.08 log units) below what was measured; the measured number falls inside the stated range.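

In this assay, methylsulfonyl to sulfamoyl on the second core gives a 1.0-fold higher number from compound 3 to compound 4 (0.01 log units; within the scatter), so no effect of the change can be read on this core, as on the first. Set side by side, the two steps agree: the same change on two cores in this assay, a 1.2-fold lower number (0.07 log units; within the scatter) from compound 1 to compound 2 and a 1.0-fold higher number (0.01 log units; within the scatter) from compound 3 to compound 4, 1.2-fold (0.07 log units) apart, within the scatter of two such steps. This shows that, on these two cores and in this one assay, amino in place of methyl on a sulfonyl sulfur gave no step beyond the scatter; it does not show that a measurable effect carries from one core to the other, since neither step gives a size to carry, nor does it show how the change would behave on any further core or in any other assay.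

Still open, going by these compounds, is whether any other group at this place would give a step beyond the scatter, for instance methylamino or dimethylamino on the sulfonyl sulfur, or a carboxylic acid or a nitrile in place of the whole methylsulfonyl group. Also open, on these data alone, is how the rest of the molecule bears on these numbers, for instance with an amide in place of the ester or a longer chain in place of the link from the sulfur to the ester oxygen.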